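From 4-ethylphenyl to 3-fluorophenyl on an amine nitrogen

The source may hold more compounds than are shown below. What is called first, only, known or untested is meant among the compounds shown, and "the series" means these compounds.

Compound 1 `CCCc1ccc(NC2=CC(=O)c3nc4n(c3C2=O)[C@H]2OC[C@@H](O)[C@H]2OC4)cc1`: 1560 nM
Compound 2 `CCc1ccc(NC2=CC(=O)c3nc4n(c3C2=O)[C@H]2OC[C@@H](O)[C@H]2OC4)cc1`: 1290 nM

For the measured compounds named here, in a functional assay on MGC-803 cells (Homo sapiens) for inhibition, read by sulforhodamine B assay (on this read-out higher numbers stand for weaker inhibition and lower numbers for stronger inhibition), compound 2 stands level with compound 1, the only other compound measured. Compound 3 `O=C1C=C(Nc2cccc(F)c2)C(=O)c2c1nc1n2[C@H]2OC[C@@H](O)[C@H]2OC1` has 3-fluorophenyl in place of 4-ethylphenyl on an amine nitrogen. Going by the values given here, the only measured step is a 1.2-fold lower number from compound 1 to compound 2 (0.08 log units; within the scatter). Among the compounds with values here, it concerns the saturated chain alone, and no measured compound carries 3-fluorophenyl, so it offers only weak guidance. In this assay the expected change is a 1.1-fold lower number from compound 2 to compound 3 (0.03 log units; within the scatter), which means none beyond the scatter and no favoured direction. The estimate for compound 3 is 1200 nM, with a range from 400 nM to 3600 nM.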

Compound 3, half-maximal inhibitory concentration: 2180 nM
Compound 3: middle estimate off by 1.8-fold (0.26 log units), on the low side; the range from low to high includes it.
By their numbers in this assay, from the lowest: compounds 2, 1 and 3 (each within the scatter of the next).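

In this assay the amine nitrogen carries 3-fluorophenyl in place of 4-ethylphenyl with a 1.7-fold higher number from compound 2 to compound 3 (0.23 log units; within the scatter) and in place of 4-propylphenyl with a 1.4-fold higher number from compound 1 to compound 3 (0.15 log units; within the scatter) as the matching step. The three compounds therefore stand level, and this position now shows no separation for a change of the whole aryl group, where the earlier step covered only the saturated chain. Nothing available explains this result. The compounds shown leave open whether a carboxylic acid or an amine on the phenyl ring would separate from these values. On these data alone, whether a cyclohexyl group on the nitrogen would do so also stays open.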